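The compounds below may be only part of what the source reports. "The series", "measured", "known", "first", "only" and "open" are said of these compounds alone.

Measured in a functional assay on M21 cells (Homo sapiens) for antiproliferative activity, read by sulforhodamine B assay, with a stated time of 48 h; a lower number here means a stronger inhibitor, a higher number a weaker inhibitor:
- Compound 1 `O=C1NCCN1c1ccc(S(=O)(=O)Nc2ccc(C3CCCCC3)cc2)cc1`: > 1000 nM, a limit
- Compound 2 `Cc1ccc(NS(=O)(=O)c2ccc(N3CCNC3=O)cc2)cc1`: 260 nM
- Compound 3 `CC(C)(C)c1ccc(NS(=O)(=O)c2ccc(N3CCNC3=O)cc2)cc1`: > 1000 nM, a limit

Of the three, compound 2 alone has a number, 260 nM. Compound 4 `O=C1NCCN1c1ccc(S(=O)(=O)Nc2ccc(F)c(F)c2)cc1` differs from it as follows: 3,4-difluorophenyl in place of 4-methylphenyl on a sulfonamide nitrogen. Going by the values given here, two measured steps bear on this change: an at least 3.8-fold lower number from compound 1 to compound 2 (0.58 log units; beyond the scatter) and an at least 3.8-fold higher number from compound 2 to compound 3 (0.58 log units; beyond the scatter). Both lie beyond the scatter, and each is read against a limit. Both concern larger groups on an aromatic carbon, and neither involves fluorine, so they are only a loose guide. A small rise in the number is expected in this assay, with the expected step being a 1.5-fold higher number from compound 2 to compound 4 (0.19 log units; within the scatter). Compound 4 is estimated at 400 nM. The expected range for compound 4 runs from 120 nM to 1300 nM.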

Compound 4, half-maximal inhibitory concentration: 220 nM
Beside the measured number, compound 4's estimate is 1.8-fold (0.26 log units) above it, and the stated range covers the measured number.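

Exchanging 4-methylphenyl for 3,4-difluorophenyl on the sulfonamide nitrogen gives, in this assay, a 1.2-fold lower number from compound 2 to compound 4 (0.07 log units; within the scatter). This position therefore accepts this fluorine-bearing group with a measurable read-out and no change beyond the scatter. That contrasts with compound 1 and compound 3, whose results are limits rather than numbers: the limit of > 1000 nM in this assay, at which 2 of the 4 values shown sit.

Still open, from the compounds shown here alone, is whether a single fluorine would read like 3,4-difluorophenyl. Also open, going by these compounds, is how a methoxy group, an amine or a carboxylic acid on this phenyl ring would read.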